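Working notes on an ester variant of compound 1

This account rests on a few compounds, and the source may have more. Where it says the series, first, only, none or still open, it means among the compounds named here.

Among the measured compounds shown here, compound 1 `Cc1cc(NC(=O)Nc2ccc(N)cc2)c2ccccc2n1` is one of three compounds measured in an ADME assay on BJ cells (Homo sapiens) for cytotoxicity, with a stated time of 72 h; a lower number here means that less compound is needed, a higher number that more compound is needed for the effect. In this assay compound 1 gives > 25000 nM, which is a limit of the assay and not a number. Compound 2 `Cc1cc(NC(=O)Nc2ccccc2F)c2ccccc2n1` gives > 25000 nM, also a limit. Compound 3 `Cc1cc(NC(=O)Nc2cccc(Cl)c2)c2ccccc2n1` gives > 25000 nM, again a limit. The steps a step that the two limits leave unreadable from compound 1 to compound 2, a step that the two limits leave unreadable from compound 1 to compound 3 and a step that the two limits leave unreadable from compound 2 to compound 3 therefore have no readable size; all that the measured set shows is the limit of > 25000 nM in this assay, at which 3 of the 3 values shown sit.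

Compound 4 `COC(=O)c1ccc(NC(=O)Nc2cc(C)nc3ccccc23)cc1` differs from compound 1 in one place: methoxycarbonyl in place of amino on an aromatic carbon. For the measured compounds named here, none of the measured steps was read as a number, so no direction or size can be taken from them for this change. With every measured value sitting at the limit, the expectation for compound 4 is that this assay will again report only a limit or a value close to it. Compound 4 is estimated at 30000 nM, with a range from 12000 nM to 90000 nM. The step that this estimate means is a step that the limit leaves unreadable from compound 1 to compound 4, expected to stay within the scatter. The estimate rests on limits alone and is weakly anchored.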

Compound 4, half-maximal effective concentration: 21000 nM
Beside the measured number, compound 4's estimate is 1.4-fold (0.15 log units) above it, and the stated range covers the measured number.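

Compound 4 is the first of the compounds shown for which this assay returns a number and not a limit, so methoxycarbonyl in place of amino, on an aromatic carbon para to a large group, gives the first measured reading at this position. On these data alone, the change reads as an at least 1.1-fold lower number from compound 1 to compound 4 (0.07 log units; that floor lies within the scatter); one end of this step is a limit, so it gives only a floor, and the true size of the step stays unknown. The steps among compound 1, compound 2 and compound 3 cannot be read, and the number for compound 4 stands apart from the rest of the set: the limit of > 25000 nM in this assay, at which 3 of the 4 values shown sit.

As far as these compounds go, what stays open is whether this reading belongs to the ester as such, and a carboxylic acid or an ethyl ester in place of methoxycarbonyl on the same aromatic carbon would test that. It is also open how the methoxycarbonyl group would read on the ring of compound 2 or compound 3, where a fluorine or chlorine atom is already present, and no measured property in the compounds shown gives a cause for the change.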